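The source may report more compounds than this note shows. Statements on the series, on what has been measured and on what is new or still open speak of the compounds shown alone.

The measured compounds:

Compound 1, `CCn1nc(C#Cc2cc(C(=O)Nc3cccc(C(F)(F)F)c3)ccc2C)c2c(N)ncnc21`: in an ADME assay on HepG2 cells (Homo sapiens) for antiproliferative activity, read by MTT assay, with a stated time of 72 h (on this read-out lower numbers stand for stronger inhibition and higher numbers for weaker inhibition), compound 1 gives only a limit of the assay, > 10000 nM.
Compound 2, `Cc1ccc(C(=O)Nc2cccc(C(F)(F)F)c2)cc1C#Cc1nn(CC2CCN(C)C2)c2ncnc(N)c12`: in this assay compound 2 gives 3500 nM.
Compound 3, `CN1CCC(n2nc(C#Cc3cccc(C(=O)Nc4cccc(C(F)(F)F)c4)c3)c3c(N)ncnc32)CC1`: in this assay compound 3 likewise gives only a limit, > 10000 nM.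

Compound 3 therefore stands at the limit rather than at a number, and it shares that standing with one other compound, as the limit of > 10000 nM in this assay, at which 2 of the 3 values shown sit, shows. Compound 4, `CN1CCC(n2nc(C#Cc3cc(C(=O)Nc4cccc(C(F)(F)F)c4)ccc3Cl)c3c(N)ncnc32)CC1`, differs from compound 3 by chloro in place of hydrogen on an aromatic carbon. Going by the values given here, the single measured step, an at least 2.8-fold lower number from compound 1 to compound 2 (0.45 log units; beyond the scatter), changes the group on a saturated chain carbon bound to an aromatic nitrogen, not the six-membered aromatic ring of carbon only, so no measured step bears directly on the chloro change. With compound 3 giving only > 10000 nM, the starting point is itself a limit. Compound 4 is therefore expected to show a step of about an at least 1.1-fold lower number from compound 3 to compound 4 (0.04 log units; that floor lies within the scatter), not beyond the scatter. Compound 4 is estimated at 9000 nM, with a range from 2500 nM to 30000 nM.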

Compound 4, half-maximal inhibitory concentration: > 10000 nM
Compound 4 was reported as a limit; the forecaster's own chance of this, stated with the estimate: 60%; at least 1.1-fold (0.04 log units) between middle value and limit.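

Compound 3 and compound 4 both give only a limit in this assay, so the step between them cannot be read: the limit of > 10000 nM in this assay, at which 3 of the 4 values shown sit.

The compounds shown leave open whether chloro in place of hydrogen on this aromatic carbon changes the antiproliferative read-out at all.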